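Esters of a carboxylic acid in a cell growth assay

The compounds below may be only part of what the source reports. "The series", "measured", "known", "first", "only" and "open" are said of these compounds alone.

Four related compounds are compared here. Compound 1 `C=CC(=O)Nc1ccc(Cn2nc(-c3ccc(Oc4ccccc4)cc3)cc2C(=O)O)cc1` carries a free carboxylic acid on the shared core, and compound 2 `C=CC(=O)Nc1ccc(Cn2nc(-c3ccc(Oc4ccccc4)cc3)cc2C(=O)OCC)cc1` is its ethyl ester. Compound 3 `C=CC(=O)N1CCCC(n2nc(-c3ccc(Oc4ccccc4)cc3)cc2C(=O)O)C1` carries the same acid on a different core, and compound 4 `C=CC(=O)N1CCCC(n2nc(-c3ccc(Oc4ccccc4)cc3)cc2C(=O)OCC)C1` is the ethyl ester of compound 3. How the two cores differ is not broken down here.

Activity was measured in a functional assay on Z-138 cells (Homo sapiens) for inhibition, read by luminescence and CellTiter-Glo, with a stated time of 72 h; a lower number here means a stronger inhibitor, a higher number a weaker inhibitor. Compound 1 reached only the limit of the assay, > 60000 nM, and not a number. In this assay compound 2 gives 12500 nM. Compound 3 likewise reached only the limit, > 60000 nM, and not a number.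

The change from compound 1 to compound 2 is ethyl in place of hydrogen on an oxygen next to a carbonyl group and produced an at least 4.8-fold lower number from compound 1 to compound 2 (0.68 log units; beyond the scatter). The size of this step is known only as a lower bound because the limit of > 60000 nM in this assay, at which 2 of the 3 values shown sit, leaves open how far compound 1 actually lies beyond it.

The change from compound 3 to compound 4 is ethyl in place of hydrogen on an oxygen next to a carbonyl group, the same change made on the other core. Since compound 3 sits at the same limit as compound 1, the same kind of gain is expected, and compound 4 is estimated to show an at least 3.0-fold lower number from compound 3 to compound 4 (0.47 log units; beyond the scatter) in this assay, a step that rests on the gain seen from compound 1 to compound 2. The expected value for compound 4 is therefore 20000 nM, estimated to fall between 6000 nM and 60000 nM.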

Compound 4, half-maximal inhibitory concentration: 44000 nM
Beside the measured number, compound 4's estimate is 2.2-fold (0.34 log units) below it, and the stated range covers the measured number.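

On the core of compound 3, putting ethyl in place of hydrogen on the oxygen next to the carbonyl group gives, in this assay, an at least 1.3-fold lower number from compound 3 to compound 4 (0.13 log units; that floor lies within the scatter). Both esters therefore give a number where both acids give only a limit, so the change points the same way on the two cores, although on the core of compound 3 the printed floor alone does not clear the usual scatter. This does not show that the gain is the same size on both cores or that it differs, because the acids give no exact starting values, and the two steps cannot be separated: the same change on two cores in this assay, an at least 4.8-fold lower number (0.68 log units; beyond the scatter) from compound 1 to compound 2 and an at least 1.3-fold lower number (0.13 log units; that floor lies within the scatter) from compound 3 to compound 4; the limit leaves it open whether they differ.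

The compounds shown leave open how far compound 1 and compound 3 actually lie beyond the limit, and so how large either step truly is. They also leave open whether a methyl ester, a longer chain such as butyl, or a primary amide in place of the ethyl ester would give the same result on both cores.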